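This account rests on a few compounds, and the source may have more. Where it says the series, first, only, none or still open, it means among the compounds named here.

Measured so far in a functional assay on the whole organism (strain Wistar) for inhibition, with Rattus norvegicus as the target, read by paw edema, with a stated time of 3 h, at a dose of 100 umol/kg by the oral route; on this read-out higher numbers stand for more inhibition at the one dose given (going by the name of the read-out) and lower numbers for less inhibition:
- compound 1 `CS(=O)(=O)c1ccc(Nc2c(-c3ccccn3)nc3ccccn23)cc1`: compound 1 gives 18.5%
- compound 2 `c1ccc(Nc2c(-c3ccccc3)nc3ccccn23)cc1`: compound 2 gives 63.9%
- compound 3 `CS(=O)(=O)c1ccc(-c2nc3ccccn3c2Nc2ccccn2)cc1`: compound 3 gives 17.2%

On these three numbers compound 1 stands second highest. Its nearest neighbour is compound 3, whose number is lower by an amount within the scatter, so the two cannot be told apart on this read-out. The furthest is compound 2, whose number is higher by an amount beyond the scatter; compound 2 is the only one of the three with a clear separation from compound 1 in this assay.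

Compound 4 `CS(=O)(=O)c1ccc(Nc2c(-c3ccncc3)nc3ccccn23)cc1` has not yet been measured in this assay. It keeps every atom of compound 1 and differs only in how they are joined: pyridin-4-yl in place of pyridin-2-yl on an aromatic carbon. Among the compounds with values here, no step between two measured compounds covers this kind of change, so there is no measured precedent for its size or direction.

Compound 1 and compound 3, the two compounds that carry a pyridinyl group and a methylsulfonyl group, both sit low in this assay and within the scatter of each other, while compound 2, which has neither, sits high. Compound 4 keeps both of those groups and is therefore expected to remain near compound 1. For compound 4 an inhibition of about 20% is expected, with a range from 5% to 40%. The expected step of a number 1.5 percentage points higher from compound 1 to compound 4 (within the scatter) is estimated to lie within the scatter, in no clear direction.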

Compound 4, a percentage reported as inhibition, in the whole organism at one dose (the size of the read-out at that dose, not a potency): 1.8%
For compound 4 the middle estimate is 18.2 percentage points above the measured one; the measured number lies below the stated range.
By their numbers in this assay, from the lowest: compound 4; then compounds 3 and 1 (each within the scatter of the next); then compound 2.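

In this assay, pyridin-4-yl in place of pyridin-2-yl on this aromatic carbon gives a number 16.7 percentage points lower from compound 1 to compound 4 (beyond the scatter), a modest step that is beyond the scatter. Within the data shown here, this is the first measured sign that the read-out at this position responds to how the pyridinyl group is joined, even though the group entering and the group leaving have the same heavy atoms and the same counts of hydrogen-bond donors and acceptors. No measurement at hand accounts for this step.

On these data alone, with only pyridin-2-yl and pyridin-4-yl compared on the otherwise unchanged compound 1 scaffold, it remains open whether pyridin-3-yl on the same carbon would stay near compound 1, fall near compound 4, or differ from both. Among these compounds, the single pair also leaves open whether the same exchange would give a step of similar size and direction with another group, such as a sulfonamide, in place of the methylsulfonyl group, or at any dose or time other than the one read here.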